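Smaller Amine on a Thiocarbonyl: Expecting Compound 3

The source may hold more compounds than are shown below. What is called first, only, known or untested is meant among the compounds shown, and "the series" means these compounds.

Compounds measured so far:
- Compound 1 `O=c1cc(CSC(=S)N2CCCC2)oc2cc(Cl)ccc12`; > 25000 nM in a functional assay on SW480 cells (Homo sapiens) for antiproliferative activity, read by MTT assay, with a stated time of 72 h (a lower number here means a stronger inhibitor, a higher number a weaker inhibitor), a limit of the assay for compound 1.
- Compound 2 `CC(C)N(C(=S)SCc1cc(=O)c2ccc(Cl)cc2o1)C(C)C`; compound 2 gives > 25000 nM, also only a limit.

Among the measured compounds shown here, the one measured step, a step that the two limits leave unreadable from compound 1 to compound 2, puts diisopropylamino in place of pyrrolidin-1-yl on a thiocarbonyl carbon; its size cannot be read because both compounds sit at the limit of > 25000 nM in this assay, at which 2 of the 2 values shown sit. Compound 2 therefore stands at the limit, with no number of its own.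

Compound 3 `CCN(CC)C(=S)SCc1cc(=O)c2ccc(Cl)cc2o1` differs from compound 2 by diethylamino in place of diisopropylamino on a thiocarbonyl carbon. For the measured compounds named here, the only related step is the unreadable one just described, so no size or direction can be drawn from it; both known compounds simply sit at the limit. Compound 3 is therefore expected to remain at the limit too, with an estimated 35000 nM between 10000 nM and 120000 nM. The step this estimate means, a step that the limit leaves unreadable from compound 2 to compound 3, is expected to be none beyond the scatter.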

Compound 3, half-maximal inhibitory concentration: > 25000 nM
Compound 3 was reported as a limit; the forecaster's own chance of this, stated with the estimate: 85%; the middle value lies beyond the limit too.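

Compound 1, compound 2 and compound 3 all stop at a limit of the assay, so no step among them can be read: the limit of > 25000 nM in this assay, at which 3 of the 3 values shown sit.

The compounds shown leave open whether any group on the thiocarbonyl carbon gives a measurable value in this assay, and how far these three groups truly differ.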